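Amide to Ester on a Shared Aryl-Pyridine Core

The source may report more compounds than this note shows. Statements on the series, on what has been measured and on what is new or still open speak of the compounds shown alone.

Compound 1 `CC(C)[C@@H](NC(=O)/C=C/c1ccncc1-c1ccc2ccccc2c1)C(=O)O` carries a (1-carboxy-2-methylpropyl)amino group on its carbonyl carbon, and in an assay on a protein complex for inhibition of CDK8/Cyclin C (Homo sapiens), with a stated time of 1 h (on this read-out lower numbers stand for stronger inhibition and higher numbers for weaker inhibition), compound 1 is recorded as "not determined" (no result reported), so no single number is known for it. Two close relatives are measured: compound 2 `O=C(/C=C/c1ccncc1-c1ccc2[nH]ccc2c1)N1CCOCC1` gives 190 nM in this assay, and compound 3 `Cn1ccc2cc(-c3cnccc3/C=C/C(=O)N3CCOCC3)ccc21` gives 247 nM. Going by the values given here, the one step recorded between them, a 1.3-fold higher number from compound 2 to compound 3 (0.11 log units; within the scatter), concerns a methyl in place of hydrogen on an aromatic nitrogen and says nothing about the carbonyl end of the molecule.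

Compound 4 `CCOC(=O)/C=C/c1ccncc1-c1ccc2ccccc2c1` differs from compound 1 in exactly that region: ethoxy in place of (1-carboxy-2-methylpropyl)amino on a carbonyl carbon. Among the compounds with values here, no measured pair shows what happens when an amide is exchanged for an ester here, so no step can be borrowed for it, and the direction of any change remains open. Within the data shown here, the only anchors are the values of compound 2 and compound 3, which share the double-bonded chain and the carbonyl but carry a different ring system and an amide rather than an ester. Given this distance, compound 4 is expected to give roughly 600 nM in this assay, with a wide range from 120 nM to 4000 nM.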

Compound 4, half-maximal inhibitory concentration: 53.3 nM
Compound 4: middle estimate off by 11-fold (1.05 log units), on the high side; measured number below the stated range.
By their numbers in this assay, from the lowest: compound 4; then compounds 2 and 3 (each within the scatter of the next).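

Going by these compounds alone, compound 1 has no single number to set against compound 4 in this assay, so no step between the two can be read. The compounds shown leave open how ethoxy in place of (1-carboxy-2-methylpropyl)amino on a carbonyl carbon shifts the read-out. No supporting evidence bears on the result for compound 4.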